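Replacing 4-hydroxyphenyl on an amide-type nitrogen

A few compounds are considered here, and "the series" means these few. Any claim that something is new, unique, unknown or untested is made for them only; others in the source may bear on it.

Values in an ADME assay for permeability, using PAMPA, at pH 7.4; a higher number here means that the compound crosses the layer faster, a lower number that the compound crosses the layer more slowly:
- compound 1 `Cc1ccc(NC(=O)Nc2cc(C)nc3ccccc23)cc1`: 669 10^-6 cm/s
- compound 2 `Cc1cc(NC(=O)Nc2ccc(O)cc2)c2ccccc2n1`: 3 10^-6 cm/s

Of the two measured compounds, compound 2 has the lower number, at 3 10^-6 cm/s. The next compound is compound 3 `Cc1cc(NC(=O)Nc2ncccc2C)c2ccccc2n1`, with this change: 3-methylpyridin-2-yl in place of 4-hydroxyphenyl on an amide-type nitrogen. Among the compounds with values here, the only measured step that bears on it is a 220-fold lower number from compound 1 to compound 2 (2.35 log units; beyond the scatter), which is large and beyond the scatter. Like compound 1 at 669 10^-6 cm/s, compound 3 carries no hydroxy, but its 3-methylpyridin-2-yl group has not been tested. A large rise in this assay is therefore expected, probably short of a full reversal of that step. The expected step is a 67-fold higher number from compound 2 to compound 3 (1.82 log units; beyond the scatter). Compound 3 is estimated at 200 10^-6 cm/s, with an expected range of 40 10^-6 cm/s to 700 10^-6 cm/s.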

Compound 3, apparent permeability: 369 10^-6 cm/s
Beside the measured number, compound 3's estimate is 1.8-fold (0.27 log units) below it; low and high end bracket the measured number.
By their numbers in this assay, from the lowest: compound 2; then compounds 3 and 1 (each within the scatter of the next).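

In this assay a ring with a hetero atom is compatible with a high number at this amide-type nitrogen: the change from 4-hydroxyphenyl to 3-methylpyridin-2-yl gives a 120-fold higher number from compound 2 to compound 3 (2.09 log units; beyond the scatter) on the shared core. Against 4-methylphenyl, the same group gives a 1.8-fold lower number from compound 1 to compound 3 (0.26 log units; within the scatter), so these two groups cannot be told apart here. No evidence on hand accounts for either step. As far as these compounds go, the separate contributions of the ring nitrogen and the methyl of 3-methylpyridin-2-yl remain open. So does the reading in this assay for an amine or a carboxylic acid on this ring.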